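Chain shortening at the ether-linked tail of compound 3

This account rests on a few compounds, and the source may have more. Where it says the series, first, only, none or still open, it means among the compounds named here.

Three compounds have numbers in an assay on isolated protein for displacement of a labelled ligand from leukotriene B4 receptor 1 (Homo sapiens) (a higher number here means a weaker inhibitor, a lower number a stronger inhibitor), so far. Compound 1 `COc1ccc(CCCCCCCCOc2ccc(CS(=O)(=O)Cc3cccc(C(=O)O)c3)nc2/C=C/C(=O)O)cc1` gives 53 nM, compound 2 `COc1ccc(CCCCCCCCOc2ccc(CSCc3cccc(C(=O)O)c3)nc2CCC(=O)O)cc1` gives 8 nM, and compound 3 `O=C(O)/C=C/c1nc(CSCc2cccc(C(=O)O)c2)ccc1OCCCCCCCCc1ccccc1` gives 15.4 nM. Among these, compound 3 holds the second highest number; its nearest neighbour is compound 2, and the gap between the two lies within the scatter of this assay, so no order between compound 2 and compound 3 can be read from these values. The gap to compound 1 is the widest and lies beyond the scatter, with compound 1 the weaker inhibitor of the pair.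

Compound 4 `COc1ccc(CCCCOc2ccc(CSCc3cccc(C(=O)O)c3)nc2/C=C/C(=O)O)cc1` has not yet been measured in this assay. Its structure differs from compound 3 in one place: 4-methoxyphenyl in place of 4-phenylbutyl on a saturated chain carbon, four bonds along the chain from an oxygen on an aromatic ring. Within the data shown here, no step between measured compounds matches this change, so any expectation rests on the shared core only. The shortened tail is expected to cost some binding, and the step in this assay from compound 3 to compound 4 is estimated as a 3.2-fold higher number from compound 3 to compound 4 (0.51 log units; beyond the scatter). Compound 4 is therefore expected to give about 50 nM, within a range from 12 nM to 250 nM.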

Compound 4, inhibition constant: 9.2 nM
Beside the measured number, compound 4's estimate is 5.4-fold (0.74 log units) above it; measured number outside the range, below it.
By their numbers in this assay, from the lowest: compounds 2, 4 and 3 (each within the scatter of the next); then compound 1.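

In this assay, 4-methoxyphenyl in place of 4-phenylbutyl on a saturated chain carbon, four bonds along the chain from an oxygen on an aromatic ring, gives a 1.7-fold lower number from compound 3 to compound 4 (0.22 log units; within the scatter) and so shows no loss of binding that can be read. This position therefore accepts a tail with fewer heavy atoms, with an added hydrogen-bond acceptor, while the rest of the structure stays fixed. Nothing shown accounts for this tolerance.

Among these compounds, the single step changes chain length and adds the methoxy group together, so the share of each cannot be separated. On these data alone, whether a still shorter chain, or an amine or a carboxylic acid at the end of the tail, would be accepted at this position remains open.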